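Lengthening the chain on the shared core

A few compounds are considered here, and "the series" means these few. Any claim that something is new, unique, unknown or untested is made for them only; others in the source may bear on it.

Compound 1 `CCCCCCCCCCCCCCCCCC/N=c1\nc(N)c2nc[nH]c2c(N)n1`: 3530 nM
Compound 2 `CCCCCCCC/N=c1\nc(N)c2ncn(Cc3ccc(F)cc3)c2c(N)n1`: 3000 nM
Compound 3 `CC/N=c1\nc(N)c2nc[nH]c2c(N)n1`: > 100000 nM

In a functional assay on MCF7 cells (Homo sapiens) for antiproliferative activity, read by WST assay, with a stated time of 72 h (a lower number here means a stronger inhibitor, a higher number a weaker inhibitor), compound 1 gives 3530 nM and compound 2 gives 3000 nM; these two values lie within the usual scatter of each other. For compound 3 this assay reports only a limit, > 100000 nM, so compound 3 stands at the limit of > 100000 nM in this assay, at which 1 of the 3 values shown sits, rather than at a number. Compound 4 `CCCCCCCC/N=c1\nc(N)c2nc[nH]c2c(N)n1` has not yet been measured. It differs from compound 3 by hexyl in place of hydrogen on a saturated chain carbon, two bonds along the chain from a double-bonded nitrogen. Compound 1 carries a still longer chain and compound 2 a chain of the same length as compound 4, both with numbers well inside the assay. Since compound 1 gives 3530 nM, the expected step is an at least 20-fold lower number from compound 3 to compound 4 (1.30 log units; beyond the scatter), a large move toward a stronger inhibitor. Compound 4 is therefore expected to give 5000 nM in this assay, within 1500 nM to 20000 nM.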

Compound 4, half-maximal inhibitory concentration: "not active" (no number reported)
Compound 4: no number reported; the estimate stays without a comparison.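

No step can be read from compound 3 to compound 4: compound 4 is reported as not active, without a number, and compound 3 has only a limit. From the compounds shown here alone, how chain length alone affects activity on the shared core remains open.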